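A few compounds are considered here, and "the series" means these few. Any claim that something is new, unique, unknown or untested is made for them only; others in the source may bear on it.

Compound 2, with the structure `COc1ccccc1CN(C)CCCCn1c(=O)oc2ccccc21`, sits second highest among the three numbers measured in an assay on membranes from liver for displacement of a labelled ligand from Sigma non-opioid intracellular receptor 1 (Rattus norvegicus), read by scintillation counting; a lower number here means a stronger inhibitor, a higher number a weaker inhibitor: compound 2 gives 594 nM. Its nearest neighbour on the scale is compound 1, with the structure `Cc1cccc(CN(C)CCCn2c(=O)oc3ccccc32)c1`, which in this assay gives 1840 nM, a gap beyond the usual scatter. Furthest away is compound 3, with the structure `O=C(Nc1ccccc1)C1CCN(Cc2ccccc2)CC1`, which in this assay gives 48.1 nM, again well beyond the scatter. Compound 4, with the structure `Cc1cccc(CN(C)CCCCn2c(=O)oc3ccccc32)c1`, has not yet been measured. It differs from compound 2 in one place: 3-methylphenyl in place of 2-methoxyphenyl on a saturated chain carbon bound to an amine nitrogen. Among the measured compounds shown here, no measured pair shows this exact change on its own, so the direction is uncertain. Compound 1 also carries a 3-methylphenyl group and gave a weaker value, but other parts of that molecule differ too, so that pair cannot be read as a clean test. The step from compound 2 to compound 4 is therefore expected to be small, roughly a 1.7-fold higher number from compound 2 to compound 4 (0.23 log units; within the scatter), towards a slightly weaker inhibitor. Compound 4 is estimated at 1000 nM, within a range from 400 nM to 2500 nM.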

Compound 4, inhibition constant: 102 nM
Compound 4: the middle estimate sits 9.8-fold (0.99 log units) above what was measured; the measured number lies below the stated range.
By their numbers in this assay, from the lowest: compound 3; then compound 4; then compound 2; then compound 1.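

Among the compounds shown here, the group on the saturated chain carbon bound to an amine nitrogen matters more in this assay than the earlier compounds could show: with 3-methylphenyl in place of 2-methoxyphenyl and the rest of the molecule unchanged, the result is a stronger inhibitor (a 5.8-fold lower number from compound 2 to compound 4 (0.77 log units; beyond the scatter)), a step beyond the scatter. For the compounds shown here, this is the first clean reading of this change, and it shows that a swap between two similar-sized phenyl groups can shift the number substantially. Nothing available explains why the step is this large.

The change alters both the substituent and its numbered place on the ring, so the effects of the two cannot be separated here. A 3-methoxyphenyl or 2-methylphenyl group at this position would separate them, and an unsubstituted phenyl group would show whether either substituent is needed at all.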